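Azido to Amino Exchange Across Two Shared Cores

The compounds below may be only part of what the source reports. "The series", "measured", "known", "first", "only" and "open" are said of these compounds alone.

Compound 1 `[N-]=[N+]=Nc1cc(=O)[nH]c(=O)n1[C@@H]1O[C@H](CO)[C@@H](O)[C@H]1O` carries an azido group on its core. In a functional assay on OVCAR-4 cells (Homo sapiens) for antiproliferative activity, read by WST assay, with a stated time of 3 days (on this read-out higher numbers stand for weaker inhibition and lower numbers for stronger inhibition), compound 1 gives > 50000 nM, which is a limit of the assay and not a number. Compound 2 `Nc1cc(=O)[nH]c(=O)n1[C@@H]1O[C@H](CO)[C@@H](O)[C@H]1O` differs from compound 1 through (amino in place of azido on an aromatic carbon). In this assay compound 2 gives > 50000 nM, again a limit rather than a number. The step that the two limits leave unreadable from compound 1 to compound 2 cannot be read because the two values sit at the limit of > 50000 nM in this assay, at which 2 of the 3 values shown sit.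

Compound 3 `[N-]=[N+]=Nc1c(F)c(=O)[nH]c(=O)n1[C@@H]1O[C@H](CO)[C@@H](O)[C@H]1O` differs from compound 1 through (fluoro in place of hydrogen on an aromatic carbon). In this assay, among the compounds with values here, compound 3 gives 1500 nM, the only number among the three measured compounds. This is the step of an at least 33-fold lower number from compound 1 to compound 3 (1.52 log units; beyond the scatter).

Compound 4 `Nc1c(F)c(=O)[nH]c(=O)n1[C@@H]1O[C@H](CO)[C@@H](O)[C@H]1O` has not yet been measured in this assay; it differs from compound 3 through (amino in place of azido on an aromatic carbon). Within the data shown here, this is the same kind of change as the one from compound 1 to compound 2, but the place is not the same word for word: in compound 4 the aromatic carbon is ortho to a fluoro group, which the place in compound 1 lacks. Because the earlier step that the two limits leave unreadable from compound 1 to compound 2 is unreadable, the expectation for compound 4 rests only on the structural change and on the value of compound 3. The step is expected to be an 8.0-fold higher number from compound 3 to compound 4 (0.90 log units; beyond the scatter), a weakening on balance. Compound 4 is estimated to give 12000 nM in this assay, expected to fall between 2000 nM and 50000 nM.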

Compound 4, half-maximal inhibitory concentration: 2000 nM
The estimate for compound 4 lay 6.0-fold (0.78 log units) above the measured number; measured number inside the range.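

In this assay, the exchange of azido for amino on the core that bears the fluoro group comes to a 1.3-fold higher number from compound 3 to compound 4 (0.12 log units; within the scatter), so on this core the exchange leaves the number within the usual scatter. On these data alone, the same exchange on the core of compound 1 cannot be read, and it stays unknown whether the result on the fluoro core carries over to the core without fluoro, because compound 1 and compound 2 both sit at a limit of the assay and not at a number: the limit of > 50000 nM in this assay, at which 2 of the 4 values shown sit. What does appear on both cores is the other change, fluoro in place of hydrogen, which gives an at least 25-fold lower number from compound 2 to compound 4 (1.39 log units; beyond the scatter) and is large with azido and with amino alike, though its size on the two cores cannot be compared exactly: the same change on two cores in this assay, an at least 33-fold lower number (1.52 log units; beyond the scatter) from compound 1 to compound 3 and an at least 25-fold lower number (1.39 log units; beyond the scatter) from compound 2 to compound 4; the limit leaves it open whether they differ.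

The compounds shown leave open how far the exchange of azido for amino reaches on the core without fluoro, where only limits stand. They also leave open whether a chloro or methyl group in place of the fluoro group, or a methylamino or methoxy group in place of the amino group, would keep the number seen for compound 4.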